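The source may report more compounds than this note shows. Statements on the series, on what has been measured and on what is new or still open speak of the compounds shown alone.

Measured so far:
- Compound 1, `CC(C)CCN(CCCCCCC(=O)NO)c1ncc(C(=O)NCc2cccnc2)s1`: 220 nM
- Compound 2, `CC(C)CCN(CCCCCC(=O)NO)c1ncc(C(=O)NCCCn2ccnc2)s1`: 20 nM

Among the measured compounds shown here, in an assay on isolated protein for inhibition of Nicotinamide phosphoribosyltransferase (Homo sapiens), read by fluorescence, with stated times of 5 min and 15 min (a higher number here means a weaker inhibitor, a lower number a stronger inhibitor), compound 2 gives the lowest number of the two, and compound 1 sits beyond the scatter with its higher number; the two differ in more than one place, so no single step between them can be read off. Compound 3, `CC(C)CCN(CCCCCCC(=O)NO)c1ncc(C(=O)NCCCn2ccnc2)s1`, is compound 2 with one change: (hydroxycarbamoyl)methyl in place of hydroxycarbamoyl on a saturated chain carbon, five bonds along the chain from a nitrogen on an aromatic ring. The hydroxamic acid end is thus moved one chain carbon further out, while the amide side of compound 2 is kept. Nothing measured speaks directly to this chain lengthening, since compound 1 carries the longer chain together with a different amide side. The expectation is therefore cautious: a step from compound 2 to compound 3 of a 2.0-fold higher number from compound 2 to compound 3 (0.30 log units; within the scatter), a small weakening that may well stay within the scatter. Compound 3 is estimated at 40 nM, with a range from 12 nM to 130 nM.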

Compound 3, half-maximal inhibitory concentration: 15 nM
Compound 3: the middle estimate sits 2.7-fold (0.43 log units) above what was measured; the range from low to high includes it.
By their numbers in this assay, from the lowest: compounds 3 and 2 (each within the scatter of the next); then compound 1.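

With the amide side held fixed, (hydroxycarbamoyl)methyl in place of hydroxycarbamoyl gives a 1.3-fold lower number from compound 2 to compound 3 (0.12 log units; within the scatter) in this assay and so the two compounds cannot be told apart, which means this position accepts one extra chain carbon with no measurable effect. With the chain held fixed instead, 2-(1H-imidazol-1-yl)ethyl in place of pyridin-3-yl on the amide side gives a 15-fold lower number from compound 1 to compound 3 (1.17 log units; beyond the scatter) and this isolates a large effect of the amide side, which the two earlier compounds, differing in two places, could not show. Nothing measured here offers a reason for either result.

Still open, as far as these compounds go, is whether a longer chain, such as 3-(hydroxycarbamoyl)propyl, would be accepted equally well. Also open, from the compounds shown here alone, is what a carboxylic acid would do in place of the hydroxycarbamoyl end.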